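This account rests on a few compounds, and the source may have more. Where it says the series, first, only, none or still open, it means among the compounds named here.

Three compounds have been tested in a functional assay on 4T1 cells (Mus musculus) for cytotoxicity, read by MTT assay, with a stated time of 48 h (a lower number here means a stronger inhibitor, a higher number a weaker inhibitor), and each result is a limit rather than a number:

Compound 1 `COc1ccc(OC)c(/C=C/C(=O)/C=C/c2cc3ccccc3nc2Oc2ccc(Br)cc2)c1`: > 10000 nM
Compound 2 `COc1ccc(/C=C/C(=O)/C=C/c2cc3ccccc3nc2Oc2ccc(Br)cc2)cc1OC`: > 10000 nM
Compound 3 `COc1cc(OC)c(/C=C/C(=O)/C=C/c2cc3ccccc3nc2Oc2ccc(Br)cc2)c(OC)c1`: > 10000 nM

The position of compound 2 is therefore known only as a limit, > 10000 nM. It shares this position with the other two compounds, as the limit of > 10000 nM in this assay, at which 3 of the 3 values shown sit, shows.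

Compound 4 `COc1ccc(/C=C/C(=O)/C=C/c2cc3ccccc3nc2Oc2cccc(Cl)c2)cc1OC` departs from compound 2 at a single place: 3-chlorophenyl in place of 4-bromophenyl on an oxygen on an aromatic ring. In words, 3-chlorophenyl stands in place of 4-bromophenyl on an oxygen on an aromatic ring.

For the measured compounds named here, no measured step touches that group. The three available steps, a step that the two limits leave unreadable from compound 1 to compound 2, a step that the two limits leave unreadable from compound 1 to compound 3 and a step that the two limits leave unreadable from compound 2 to compound 3, change only the methoxy-substituted phenyl group on the chain, and none has a readable size. They offer no size or direction to carry over to the new change. What they do show is that three variations at the other end of the molecule all left the result at the limit.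

Compound 4 is therefore expected to stay close to that limit, quite possibly returning only a limit itself. The expected change is a step that the limit leaves unreadable from compound 2 to compound 4, an estimate with no firm direction behind it. For compound 4 the estimated value is 12000 nM, with an expected range from 4000 nM to 30000 nM.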

Compound 4, half-maximal inhibitory concentration: > 10000 nM
Compound 4: no number, only a limit; the forecaster's own chance of this, stated with the estimate: 70%; the middle value is on the limit's open side.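

In this assay compound 4 gives > 10000 nM, which is a limit and not a number. For the compounds shown here, compound 2 also stands only at a limit, so no step between compound 2 and compound 4 can be read. The compounds shown leave open how 3-chlorophenyl and 4-bromophenyl on that oxygen compare, and what any of the four compounds' actual values are.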